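The source may hold more compounds than are shown below. What is called first, only, known or untested is meant among the compounds shown, and "the series" means these compounds.

Measured compounds:
compound 1 `CC(C)CNC(=N)NC(=N)Nc1ccc(C(F)(F)F)cc1` with 3100 nM
compound 2 `CC(C)CNC(=N)NC(=N)Nc1ccc(F)c(F)c1` with 42900 nM
compound 3 `CCN(CC)C(=N)NC(=N)Nc1ccc(F)c(F)c1` with 44800 nM

In a functional assay on T-24 cells (Homo sapiens) for antiproliferative activity, read by MTT assay, with a stated time of 72 h (on this read-out higher numbers stand for weaker inhibition and lower numbers for stronger inhibition), compound 1 gives the lowest number of the three, with its steps to compound 2 and compound 3 both beyond the scatter. Compound 1 and compound 2 differ in more than one place, and the difference between the two cores is not broken down here. From compound 2 to compound 3 the change is diethylamino in place of isobutylamino on a carbon with a double bond to nitrogen, and it made a 1.0-fold higher number from compound 2 to compound 3 (0.02 log units; within the scatter). Compound 4 `CCN(CC)C(=N)NC(=N)Nc1ccc(C(F)(F)F)cc1` is not yet measured; it differs from compound 1 by diethylamino in place of isobutylamino on a carbon with a double bond to nitrogen, the same change at the same place. The step is expected to be about a 1.0-fold higher number from compound 1 to compound 4 (0.01 log units; within the scatter), because the earlier instance gave a 1.0-fold higher number from compound 2 to compound 3 (0.02 log units; within the scatter). Compound 4 is therefore estimated at 3200 nM, most likely between 1200 nM and 9000 nM.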

Compound 4, half-maximal inhibitory concentration: 6200 nM
The estimate for compound 4 lay 1.9-fold (0.29 log units) below the measured number; the measured number falls inside the stated range.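

Carrying diethylamino in place of isobutylamino onto the core of compound 1 gave a 2.0-fold higher number from compound 1 to compound 4 (0.30 log units; within the scatter) in this assay. Set beside the earlier instance, the two steps do not differ beyond what repeated measurements allow: the same change on two cores in this assay, a 1.0-fold higher number (0.02 log units; within the scatter) from compound 2 to compound 3 and a 2.0-fold higher number (0.30 log units; within the scatter) from compound 1 to compound 4, 1.9-fold (0.28 log units) apart, within the scatter of two such steps. For the compounds shown here, the change therefore carried across these two cores with the same outcome, a step within the scatter on each, but this covers only two cores and does not show that it would behave alike on any other core.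

The compounds shown leave open what dimethylamino or piperidine would give on a carbon with a double bond to nitrogen. They also leave open whether a chloro or methoxy group in place of trifluoromethyl would keep the number of compound 1.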